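The source may report more compounds than this note shows. Statements on the series, on what has been measured and on what is new or still open speak of the compounds shown alone.

Series notes. The shared core carries, on one aromatic carbon, a group that varies across the set. Compound 1 `COc1ccc(F)cc1CNCCCNc1ccnc2cc(Oc3ccc(C(C)(C)C)cc3)ccc12` bears 4-(tert-butyl)phenoxy there, compound 2 `COc1ccc(F)cc1CNCCCNc1ccnc2cc(CC3CCCCC3)ccc12` cyclohexylmethyl, and compound 3 `COc1ccc(F)cc1CNCCCNc1ccnc2cc(Oc3ccc(Cl)cc3)ccc12` 4-chlorophenoxy. In an ADME assay for permeability, using PAMPA, with a stated time of 30 min, at pH 7.4 (on this read-out higher numbers stand for higher permeability and lower numbers for lower permeability), compound 1 gives 317 10^-6 cm/s, compound 2 gives 23 10^-6 cm/s, and compound 3 gives 317 10^-6 cm/s. Compound 3 thus stands level with compound 1, the two together the highest of the three numbers, while compound 2 sits far lower: a 14-fold higher number from compound 2 to compound 3 (1.14 log units; beyond the scatter) and a 14-fold lower number from compound 1 to compound 2 (1.14 log units; beyond the scatter). Within the pair that keeps the phenoxy linkage, no change at the digits printed from compound 1 to compound 3 (within the scatter).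

Compound 4 `COc1ccc(F)cc1CNCCCNc1ccnc2cc(Oc3ccccc3)ccc12` has not been measured in this assay. Against compound 3 the difference is hydrogen in place of chloro on an aromatic carbon. Among the measured compounds shown here, the step that bears most directly on it is the one where only the group on the same aromatic carbon of the phenoxy ring changed: no change at the digits printed from compound 1 to compound 3 (within the scatter). The other two steps exchange the whole phenoxy unit for cyclohexylmethyl and say little about a change of this kind. No step beyond the scatter is therefore expected in this assay, that is a 1.1-fold lower number from compound 3 to compound 4 (0.02 log units; within the scatter). Compound 4 is expected to give about 300 10^-6 cm/s, in the range 150 10^-6 cm/s to 500 10^-6 cm/s.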

Compound 4, apparent permeability: 317 10^-6 cm/s
Estimate against measurement, compound 4: 1.1-fold (0.02 log units) below; low and high end bracket the measured number.
By their numbers in this assay, from the lowest: compound 2; then compounds 1, 3 and 4 (each within the scatter of the next).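

In this assay the place on the aromatic carbon para to a large group now holds hydrogen as well as chloro and tert-butyl, and taking the substituent away altogether leaves the read-out unmoved (no change at the digits printed from compound 3 to compound 4 (within the scatter); no change at the digits printed from compound 1 to compound 4 (within the scatter)). The unsubstituted phenoxy keeps the full gap to the cyclohexylmethyl group (a 14-fold higher number from compound 2 to compound 4 (1.14 log units; beyond the scatter)), so among these compounds the large step needs no substituent on the phenoxy ring and goes with the exchange of the whole phenoxy unit. Nothing available explains either the flat result at this place or the large step.

On these data alone, the three phenoxy compounds share one printed number, so it remains open whether any group at this place can shift the read-out, for instance an amine or a carboxylic acid in place of chloro. As far as these compounds go, it also remains open whether the large step follows the oxygen link or the aromatic ring, a question that cyclohexyloxy or benzyl on the same carbon of the shared core would separate.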